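Adding a nitro group to compound 1

A few compounds are considered here, and "the series" means these few. Any claim that something is new, unique, unknown or untested is made for them only; others in the source may bear on it.

Compound 1 (`COc1cc(CCc2ccccc2)cc(OC)c1O`) is the starting point in a functional assay on MDA-MB-231 cells (Homo sapiens) for antiproliferative activity, read by MTT assay, with a stated time of 72 h; a higher number here means a weaker inhibitor, a lower number a stronger inhibitor. There compound 1 gives > 25000 nM, which is a limit of the assay and not a number. Compound 1 thus sits at the limit of > 25000 nM in this assay, at which 1 of the 2 values shown sits.

Compound 3 (`COc1cc(CCc2ccc([N+](=O)[O-])cc2)cc(OC)c1O`) differs from it in one place: nitro in place of hydrogen on an aromatic carbon. This is nitro in place of hydrogen on an aromatic carbon, para to a large group.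

Within the data shown here, only one measured step bears on this change. Compound 2 (`COc1cc(CCc2ccccc2F)cc(OC)c1O`) carries fluoro in place of hydrogen on an aromatic carbon and gives 9220 nM. That step, an at least 2.7-fold lower number from compound 1 to compound 2 (0.43 log units; beyond the scatter), lies beyond the scatter, although it starts from a limit and involves a different group. A modest move towards a lower number is therefore expected, but compound 3 may also be reported only as a limit.

The expected step is an at least 2.0-fold lower number from compound 1 to compound 3 (0.31 log units; beyond the scatter).

The estimated value for compound 3 is 12000 nM, within a range of 4000 nM to 30000 nM.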

Compound 3, half-maximal inhibitory concentration: 8050 nM
The estimate for compound 3 lay 1.5-fold (0.17 log units) above the measured number, within the range that was stated.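

In this assay, putting a nitro group on this aromatic carbon, para to a large group, brings an at least 3.1-fold lower number from compound 1 to compound 3 (0.49 log units; beyond the scatter), so this position can carry a nitro group with a gain in antiproliferative activity. Until now only fluoro had given a step of this kind, and that was at a different place on the ring, so a nitro group here is a second, separate case. The true size of the step remains unknown, because compound 1 gives only a limit and not a number: the limit of > 25000 nM in this assay, at which 1 of the 3 values shown sits.

On these data alone, whether this gain belongs to the nitro group itself or would follow other groups at this position stays open, and an amine or a carboxylic acid in the same place would test that. Also open, as far as these compounds go, is whether a nitro group on another carbon of this ring would do the same.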